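A few compounds are considered here, and "the series" means these few. Any claim that something is new, unique, unknown or untested is made for them only; others in the source may bear on it.

Of the compounds shown here, three that share one core have been measured in an assay on microsomes for inhibition of acyl-CoA:cholesterol acyltransferase (Oryctolagus cuniculus); a higher number here means a weaker inhibitor, a lower number a stronger inhibitor. Compound 1 `CC(C)c1cccc(C(C)C)c1NC(=O)NCC1(c2ccc(C(C)(C)C)cc2)CCCC1` gives 63 nM in this assay, the highest of the three numbers, so it is the weakest inhibitor of the group. Compound 2 `COc1cccc(C2(CNC(=O)Nc3c(C(C)C)cccc3C(C)C)CCCC2)c1` gives 13 nM in this assay, and compound 3 `CC(C)c1cccc(C(C)C)c1NC(=O)NCC1(c2ccccc2C(F)(F)F)CCCC1` gives 18 nM. Compound 4 `CC(C)c1cccc(C(C)C)c1NC(=O)NCC1(c2cccc(N)c2)CCCC1` has not yet been measured in this assay; it differs from compound 1 in one place: 3-aminophenyl in place of 4-(tert-butyl)phenyl on a saturated ring carbon.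

Within the data shown here, two measured steps bear on this change, since each of them also swaps the 4-(tert-butyl)phenyl of compound 1 for another aromatic group on the same saturated ring carbon: a 4.8-fold lower number from compound 1 to compound 2 (0.69 log units; beyond the scatter) and a 3.5-fold lower number from compound 1 to compound 3 (0.54 log units; beyond the scatter). Both run in the same direction and both are modest in size. The 3-aminophenyl of compound 4 is, in its pattern of attachment, closest to the 3-methoxyphenyl of compound 2, so the expected step is a 3.2-fold lower number from compound 1 to compound 4 (0.50 log units; beyond the scatter), a modest lowering of the number. Compound 4 is therefore estimated at 20 nM in this assay, with a range from 7 nM to 60 nM.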

Compound 4, half-maximal inhibitory concentration: 21 nM
Compound 4: middle estimate off by 1.1-fold (0.02 log units), on the low side; low and high end bracket the measured number.
By their numbers in this assay, from the lowest: compounds 2, 3 and 4 (each within the scatter of the next); then compound 1.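

In this assay, 3-aminophenyl on the saturated ring carbon also improves on 4-(tert-butyl)phenyl (a 3.0-fold lower number from compound 1 to compound 4 (0.48 log units; beyond the scatter)), making it the third replacement to move the number the same way, with no compound shown going against this. The new group also carries a hydrogen-bond donor and acceptor that 4-(tert-butyl)phenyl lacks, yet it cannot be separated from the other two replacements: amino in place of methoxy gives a 1.6-fold higher number from compound 2 to compound 4 (0.21 log units; within the scatter) and the swap from 2-(trifluoromethyl)phenyl gives a 1.2-fold higher number from compound 3 to compound 4 (0.07 log units; within the scatter). Nothing measured here explains these steps.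

On these data alone, it remains open whether the higher number of compound 1 belongs to the tert-butyl group itself or to where it sits, which a 3-(tert-butyl)phenyl or a 4-aminophenyl could help separate. How a carboxylic acid in place of the amino would fare is also unknown.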